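Adding a Methoxy Group to a Weak Deacetylase Binder

The source may hold more compounds than are shown below. What is called first, only, known or untested is meant among the compounds shown, and "the series" means these compounds.

Compound 1, `O=C(O)CCc1nc2ccccc2s1`: 180000 nM
Compound 2, `CC(Cc1nc2ccccc2s1)C(=O)O`: "not active" (no number reported)

In an assay for displacement of a labelled ligand from protein deacetylase HDAC6 (Homo sapiens), read by fluorescence polarization, with a stated time of 10 min (a lower number here means a stronger inhibitor, a higher number a weaker inhibitor), compound 1 gives 180000 nM. This is the only number reported; in this assay compound 2 is recorded only as "not active" (no number reported), without a number, so on the numbers shown compound 1 stands alone, and it stands at a very weak level. Compound 3, `COC(CC(=O)O)c1nc2ccccc2s1`, differs from compound 1 by methoxy in place of hydrogen on a saturated chain carbon bound to an aromatic carbon and a saturated chain carbon. No pair of measured compounds separated by a single change is available, so the size of this step is not shown by any measurement. Given that compound 1 gives 180000 nM, the step is expected to be small, at most a modest move toward weaker binding, and may well not exceed the usual scatter; the expected step is a 1.2-fold higher number from compound 1 to compound 3 (0.09 log units; within the scatter). Compound 3 is therefore estimated at 220000 nM, with a range from 70000 nM to 700000 nM, and a real chance that only a limit is reported.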

Compound 3, half-maximal inhibitory concentration: "not active" (no number reported)
No number was reported for compound 3; no gap can be computed for the estimate.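

In this assay, for the compounds shown here, compound 3 is recorded as "not active" (no number reported) and compound 1 has a number, so no step between compound 1 and compound 3 can be read. Nothing shown bears on this result. As far as these compounds go, how far methoxy in place of hydrogen moves binding, and in which direction, stays open.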